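A few compounds are considered here, and "the series" means these few. Any claim that something is new, unique, unknown or untested is made for them only; others in the source may bear on it.

Measured in an ADME assay on MCF7 cells (Homo sapiens) for cytotoxicity, with a stated time of 72 h; on this read-out higher numbers stand for weaker inhibition and lower numbers for stronger inhibition:

Compound 1 `COc1cccc(CNc2ncnc3c2ncn3C2CCCCO2)c1` gives 97000 nM
Compound 2 `Oc1cccc(CNc2ncnc3c2ncn3C2CCCCO2)c1O` gives > 100000 nM (a limit of the assay, not a number)

Compound 2 has no exact number in this assay and stands only at the limit of > 100000 nM in this assay, at which 1 of the 2 values shown sits, as its limit. The next compound, compound 3 `Oc1cc(O)cc(CNc2ncnc3c2ncn3C2CCCCO2)c1`, has the same atoms as compound 2, joined differently. It carries 3,5-dihydroxyphenyl in place of 2,3-dihydroxyphenyl on a saturated chain carbon bound to a nitrogen on an aromatic ring.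

For the measured compounds named here, only one measured step bears on this change. It is the step of an at least 1.0-fold higher number from compound 1 to compound 2 (0.01 log units; that floor lies within the scatter), which put 2,3-dihydroxyphenyl in place of 3-methoxyphenyl at that same place. That step rests on a limit, and its floor lies within the scatter. Going by the values given here, with only this precedent from compound 2 (> 100000 nM), no shift in either direction is foreseen for the new arrangement of the same two groups. The expected step of a number no higher from compound 2 to compound 3 (the limit leaves the size open) is therefore estimated to stay within the scatter. Compound 3 is estimated at 100000 nM with an expected range of 50000 nM to 200000 nM, and a limit rather than a number is also expected.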

Compound 3, half-maximal inhibitory concentration: > 100000 nM
Compound 3 was reported as a limit; the forecaster's own chance of this, stated with the estimate: 65%; the middle value sits exactly at the limit.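

In this assay compound 3 gives > 100000 nM, which is a limit of the assay and not a number. This shows that a second arrangement of the two hydroxyl groups on the phenyl ring, 3,5-dihydroxyphenyl, also yields no readable number at this place, so the limit is not particular to 2,3-dihydroxyphenyl, yet the step between these two compounds cannot be read, and with both reported only as limits the assay does not tell them apart: the limit of > 100000 nM in this assay, at which 2 of the 3 values shown sit.

Putting 3,5-dihydroxyphenyl in place of 3-methoxyphenyl gives an at least 1.0-fold higher number from compound 1 to compound 3 (0.01 log units; that floor lies within the scatter), so this comparison, like the one for 2,3-dihydroxyphenyl, shows no change beyond the scatter.

What the compounds shown leave open is whether the two dihydroxyphenyl arrangements differ at all at concentrations beyond the limit of this assay. They also leave open whether an amine or a carboxylic acid on the phenyl ring at this place, on a saturated chain carbon bound to a nitrogen on an aromatic ring, would give a clearly lower number than compound 1 does.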